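This account rests on a few compounds, and the source may have more. Where it says the series, first, only, none or still open, it means among the compounds named here.

Measured so far:
- compound 1, `CN1CCN(c2ccc(NC(=N)c3cc4cnn(C)c4cn3)cc2)CC1`, in a functional assay on MDA-MB-231 cells (Homo sapiens) for cytotoxicity, read by MTT assay, with a stated time of 72 h (on this read-out lower numbers stand for stronger inhibition and higher numbers for weaker inhibition), gives 30200 nM
- compound 2, `Cn1ncc2cc(C(=N)Nc3cccc(C(F)(F)F)c3)ncc21`, in this assay gives > 50000 nM

Compound 1 is the only one of the two with a real number. Compound 2 sits at the limit of > 50000 nM in this assay, at which 1 of the 2 values shown sits, so its result is a limit of the assay and not a number; all that is known is that its growth-inhibiting effect, if any, was too weak to be pinned down in this test. Compound 2 therefore stands at the weak end of what has been seen here.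

Compound 3, `Cn1ncc2cc(C(=N)Nc3ccccc3)ncc21`, has not been tested yet. It keeps the shared core and the attached benzene ring of compound 2, but differs in one place: hydrogen in place of trifluoromethyl on an aromatic carbon. Among the compounds with values here, with no measured pair of this kind to lean on, there is no basis for expecting the change to lift activity beyond the scatter, and the step from compound 2 to compound 3 is expected to be about a number no higher from compound 2 to compound 3 (the limit leaves the size open). For compound 3 the estimated result in this assay is 50000 nM, within a range of 15000 nM to 150000 nM.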

Compound 3, half-maximal inhibitory concentration: > 50000 nM
Compound 3: only a limit was reported; the forecaster's own chance of this, stated with the estimate: 65%; the middle value sits exactly at the limit.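

In this assay compound 3 gives > 50000 nM, which is a limit of the assay and not a number. With hydrogen in place of trifluoromethyl, compound 3 reports the same limit as compound 2, so the step between them cannot be read, and this change has not produced a measurable result in this test: the limit of > 50000 nM in this assay, at which 2 of the 3 values shown sit. Hydrogen in place of 4-methylpiperazin-1-yl gives an at least 1.6-fold higher number from compound 1 to compound 3 (0.21 log units; that floor lies within the scatter), so this comparison does not establish that the group matters either.

On these data alone, it remains open whether another group on that aromatic carbon, such as an amine or a carboxylic acid, would give a real number rather than a limit. As far as these compounds go, it is also open how far compound 3 truly lies from compound 1, since only a floor for that step is known.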